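Sulfonyl Aryl Variation in a Serotonin Receptor Binding Series

A few compounds are considered here, and "the series" means these few. Any claim that something is new, unique, unknown or untested is made for them only; others in the source may bear on it.

Compound 1 `COc1cccc(S(=O)(=O)c2n[nH]c3ccc(N4CCN(C)CC4)cc23)c1`: 1.1 nM
Compound 2 `CN1CCN(c2ccc3[nH]nc(S(=O)(=O)c4c(Cl)cccc4Cl)c3c2)CC1`: 2.6 nM

In an assay on HeLa cells for displacement of a labelled ligand from 5-hydroxytryptamine receptor 6 (Homo sapiens) (a lower number here means a stronger inhibitor, a higher number a weaker inhibitor), compound 2 gives the higher of the two numbers, with compound 1 nearest at a 2.4-fold higher number from compound 1 to compound 2 (0.37 log units; beyond the scatter). Compound 3 `CN1CCN(c2ccc3[nH]nc(S(=O)(=O)c4ccc(F)cc4)c3c2)CC1` carries 4-fluorophenyl in place of 2,6-dichlorophenyl on a sulfonyl sulfur. Among the compounds with values here, only the step from compound 1 to compound 2, a 2.4-fold higher number from compound 1 to compound 2 (0.37 log units; beyond the scatter), bears on this change; both aryl groups give low numbers, so compound 3 is expected to move by a 1.4-fold lower number from compound 2 to compound 3 (0.16 log units; within the scatter), a change no larger than the scatter. Compound 3 is therefore estimated at 1.8 nM, within 0.7 nM to 4.5 nM.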

Compound 3, inhibition constant: 5.2 nM
Compound 3: the middle estimate sits 2.9-fold (0.46 log units) below what was measured; measured number above the stated range.
By their numbers in this assay, from the lowest: compound 1; then compounds 2 and 3 (each within the scatter of the next).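

At this position on a sulfonyl sulfur, 4-fluorophenyl and 2,6-dichlorophenyl cannot be separated, with a 2.0-fold higher number from compound 2 to compound 3 (0.30 log units; within the scatter). Set against 3-methoxyphenyl, however, 4-fluorophenyl gives the widest step seen here, with a 4.7-fold higher number from compound 1 to compound 3 (0.67 log units; beyond the scatter), so all three aryl groups still give low numbers but do not all match. Nothing available accounts for these differences. Going by these compounds, it remains open whether a ring containing nitrogen, such as pyridyl, would keep the numbers this low. The same question stands for a non-aromatic group such as cyclohexyl or methyl on the sulfonyl sulfur.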